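The source may hold more compounds than are shown below. What is called first, only, known or untested is meant among the compounds shown, and "the series" means these compounds.

In an assay on RBL-2H3 cells for displacement of a labelled ligand from adenosine receptor A3 (Rattus norvegicus), with a stated time of 60 min (on this read-out higher numbers stand for weaker inhibition and lower numbers for stronger inhibition), compound 2 `CCCCC#Cc1nc(NCc2cccc(Cl)c2)c2ncn([C@H]3[C@H](O)[C@H](O)[C@@H]4C[C@@H]43)c2n1` gives 10.7 nM, the lowest of the two numbers at hand. For the measured compounds named here, its only measured neighbour is compound 1 `CCCCC#Cc1nc(NCc2cccc(Br)c2)c2ncn([C@H]3[C@H](O)[C@H](O)[C@@H]4C[C@@H]43)c2n1`, which in this assay gives 59 nM; the difference between them is a 5.5-fold lower number from compound 1 to compound 2 (0.74 log units; beyond the scatter).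

Compound 3 `CCCCC#Cc1nc(NCc2cccc(I)c2)c2ncn([C@H]3[C@H](O)[C@H](O)[C@@H]4C[C@@H]43)c2n1` has not yet been measured. It differs from compound 2 by the change (iodo in place of chloro on an aromatic carbon), so a third halogen now sits where chloro stood.

Going by the values given here, the one step that bears on this is the one from compound 1 to compound 2, where exchanging bromo for chloro lowered the number by a 5.5-fold lower number from compound 1 to compound 2 (0.74 log units; beyond the scatter). Going from chloro to iodo moves away from chloro again, toward a halogen that was not the one linked to the lower number, so the expectation is that the number rises rather than falls, with the halogen pair bromo and chloro as the only guide to how far.

Compound 3 is therefore estimated at 50 nM, within a range of 10 nM to 250 nM, which means an expected step of a 4.7-fold higher number from compound 2 to compound 3 (0.67 log units; beyond the scatter) in this assay.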

Compound 3, inhibition constant: 26 nM
Beside the measured number, compound 3's estimate is 1.9-fold (0.28 log units) above it, and the stated range covers the measured number.
By their numbers in this assay, from the lowest: compound 2; then compound 3; then compound 1.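

In this assay, iodo gives a number that falls between those of the other two halogens: it sits higher than chloro (a 2.4-fold higher number from compound 2 to compound 3 (0.39 log units; beyond the scatter)) yet lower than bromo (a 2.3-fold lower number from compound 1 to compound 3 (0.36 log units; beyond the scatter)). With three halogens now compared at this same ring carbon, all on the same 3-substituted benzyl group, the numbers do not climb steadily from chlorine through bromine to iodine, since bromo, the middle halogen of the three, carries the highest number and all three gaps lie beyond the usual scatter. The pair of compounds seen earlier could not reveal this, and nothing measured here offers an explanation for the order.

On these data alone, it remains open whether fluoro, the one common halogen still absent from the series, or a non-halogen group such as methyl or methoxy at this place would fall below chloro or above bromo. As far as these compounds go, it is also open whether the same order of chloro, iodo and bromo would hold if the hexynyl-type chain on the shared core were swapped for a shorter chain or an amine.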